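This account rests on a few compounds, and the source may have more. Where it says the series, first, only, none or still open, it means among the compounds named here.

Measured so far in an ADME assay on HepG2 cells (Homo sapiens) for cytotoxicity, read by CellTiter-Glo, with a stated time of 48 h; on this read-out higher numbers stand for lower toxicity in this test and lower numbers for higher toxicity in this test:
compound 1, `N#Cc1cnc(NC(=O)CCCOc2cccc(Cl)c2)s1`, gives 420 nM.
compound 2, `O=C(CCCOc1ccccc1)Nc1ncc(Br)s1`, gives 1600 nM.

Of these two numbers, compound 1 has the lowest, which here means the greater toxicity in this test; compound 2 stands at a higher number, and that gap lies beyond the usual scatter of repeated measurements. Compound 3, `N#Cc1cnc(NC(=O)CCCOc2cccc(C(F)(F)F)c2)s1`, has not yet been measured in this assay. It differs from compound 1 in one place: trifluoromethyl in place of chloro on an aromatic carbon. Within the data shown here, no pair of measured compounds shows what this exchange does to the read-out, so the present numbers give nothing to set its direction or size. The expected step is a 1.2-fold higher number from compound 1 to compound 3 (0.08 log units; within the scatter), small, in no clear direction and not beyond the scatter. Compound 3 is thus expected to give about 500 nM, within a range from 200 nM to 1300 nM.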

Compound 3, half-maximal cytotoxic concentration: 1500 nM
The estimate for compound 3 lay 3.0-fold (0.48 log units) below the measured number; the measured number lies above the stated range.
By their numbers in this assay, from the lowest: compound 1; then compounds 3 and 2 (each within the scatter of the next).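

At this place on the aromatic ring, swapping chloro for trifluoromethyl is not a neutral exchange: this assay records a 3.6-fold higher number from compound 1 to compound 3 (0.55 log units; beyond the scatter) and this step lies beyond the scatter, so the higher number stands for lower toxicity in this test. Among these compounds, this is the only measured pair that isolates a single change here, and it shows that the read-out depends on which of these two groups the ring carries. Neither group has a hydrogen-bond donor, a hydrogen-bond acceptor or a net charge, so those counts do not separate them, and nothing available explains the direction or size of the step.

As far as these compounds go, what an amine, a carboxylic acid or a methoxy group at this same place would do remains open. From the compounds shown here alone, it is also open whether this exchange gives a similar step when the nitrile on the core is replaced by another group.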